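Fluoro removal on the benzonitrile ring of the ethynylpyridine series

The source may report more compounds than this note shows. Statements on the series, on what has been measured and on what is new or still open speak of the compounds shown alone.

Measured compounds:
compound 1 `N#Cc1cc(F)cc(C#Cc2cccc(F)n2)c1`: 41 nM
compound 2 `Cc1cccc(C#Cc2cc(F)cc(C#N)c2)n1`: 0.67 nM

In an assay on membranes from brain (strain Sprague-Dawley) for displacement of a labelled ligand from metabotropic glutamate receptor 5 (Rattus norvegicus), read by scintillation counting, with a stated time of 60 min (a lower number here means a stronger inhibitor, a higher number a weaker inhibitor), compound 1 gives 41 nM, the highest of the two numbers recorded so far; its nearest neighbour is compound 2, and the step of a 61-fold lower number from compound 1 to compound 2 (1.79 log units; beyond the scatter) separates them, a change on the pyridine side of the shared core.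

Compound 3 `N#Cc1cccc(C#Cc2cccc(F)n2)c1` is not yet measured in this assay. It differs from compound 1 by hydrogen in place of fluoro on an aromatic carbon: the substituent lost sits on the six-membered aromatic ring of carbon only, meta to the cyano group and meta to the group of 9 heavy atoms.

Among the measured compounds shown here, no measured step touches this position. For the measured compounds named here, the one step known, from compound 1 to compound 2, concerns a different ring and a different pair of groups, so it does not transfer to the present change. Going by the values given here, without a comparable step, the working expectation is that the removal of fluoro on the benzonitrile ring leaves the number near that of compound 1, with no step clearly beyond the scatter. Compound 3 is therefore estimated at 50 nM, within 15 nM to 160 nM, which corresponds to the expected step of a 1.2-fold higher number from compound 1 to compound 3 (0.09 log units; within the scatter).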

Compound 3, inhibition constant: 150 nM
The estimate for compound 3 lay 3.0-fold (0.48 log units) below the measured number; the measured number falls inside the stated range.
By their numbers in this assay, from the lowest: compound 2; then compound 1; then compound 3.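

In this assay, the fluoro group on the six-membered aromatic ring of carbon only, meta to a cyano group and meta to a group of 9 heavy atoms, proves to be more than a silent passenger: hydrogen in its place gives a 3.7-fold higher number from compound 1 to compound 3 (0.56 log units; beyond the scatter). Among the compounds shown here, this is the first measured reading at this position, and it shows that the fluoro group goes with the lower number in this pair, although the step is modest beside a 61-fold lower number from compound 1 to compound 2 (1.79 log units; beyond the scatter), which arises from the change at the other end of the molecule. Nothing measured here explains why removing the fluoro group raises the number.

The compounds shown leave open whether the step from fluoro to hydrogen keeps its direction and size when the methyl group of compound 2 is present, as no pair carrying that methyl group differs at this position. They also leave open how a chloro group, a methoxy group or an amine at the same position would compare with fluoro and with hydrogen.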